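Swapping the Aryl Group on an Oxygen-Ring Core

The compounds below may be only part of what the source reports. "The series", "measured", "known", "first", "only" and "open" are said of these compounds alone.

Compound 2 `NC1=NC2(CCOCC2)N(OCCCOc2ccc(F)cc2)C(N)=N1` has "not determined" (no result reported) in an assay on isolated protein for inhibition of Dihydrofolate reductase (Homo sapiens), read by spectrophotometry, using NADPH, with stated times of 5 s and 6 min, tested at 50 uM (on this read-out lower numbers stand for a weaker effect and higher numbers for a stronger effect at the one concentration tested), so it cannot be placed against the others. Its closest measured relatives share the side chain but carry a sulfur-containing core: compound 1 `NC1=NC2(CCSCC2)N(OCCCOc2cccc(Cl)c2)C(N)=N1` gives 88.8% in this assay, and compound 3 `COc1ccc(OCCCON2C(N)=NC(N)=NC23CCSCC3)cc1` gives 86.6%. Among the measured compounds shown here, the one comparable aryl exchange, a number 2.2 percentage points lower from compound 1 to compound 3 (within the scatter), stays within the scatter. Compound 4 `Cc1cc(C)cc(OCCCON2C(N)=NC(N)=NC23CCOCC3)c1` differs from compound 2 by 3,5-dimethylphenyl in place of 4-fluorophenyl on an oxygen on a saturated carbon. Because that earlier exchange gave a number 2.2 percentage points lower from compound 1 to compound 3 (within the scatter), a step of no more than the scatter in either direction is expected here, with the absolute level carried over from compounds 1 and 3. Compound 4 is therefore expected to show about 85%, within 68% to 95%.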

Compound 4, a percentage reported as inhibition, at one concentration (the size of the read-out at that concentration, not a potency): 88.6%
Compound 4: middle estimate off by 3.6 percentage points, on the low side; measured number inside the range.
By their numbers in this assay, from the lowest: compounds 3, 4 and 1 (each within the scatter of the next).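

Among the compounds shown here, no step from compound 2 to compound 4 can be read in this assay, where compound 2 has no number for comparison. On these data alone, what exchanging 4-fluorophenyl for 3,5-dimethylphenyl does to inhibition stays open. No further data here bear on this result.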